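Cytotoxicity in a sulfonamide-triazole series: methyl to chloro

A few compounds are considered here, and "the series" means these few. Any claim that something is new, unique, unknown or untested is made for them only; others in the source may bear on it.

Measured compounds:
- compound 1 `O=c1[nH]cc(S(=O)(=O)Nc2ccccc2-c2cn(-c3cccc(Cl)c3)nn2)c(=O)[nH]1`: > 100000 nM
- compound 2 `O=c1[nH]cc(S(=O)(=O)Nc2cccc(-c3cn(-c4cccc(F)c4)nn3)c2)c(=O)[nH]1`: "not toxic" (no number reported)
- compound 3 `Cc1cccc(-n2cc(-c3ccc(NS(=O)(=O)c4c[nH]c(=O)[nH]c4=O)cc3)nn2)c1`: 39000 nM

In an ADME assay on L02 cells (Homo sapiens) for cytotoxicity, read by MTT assay, with a stated time of 24 h (on this read-out higher numbers stand for lower toxicity in this test and lower numbers for higher toxicity in this test), compound 1 reaches only the limit of the test, > 100000 nM, which is not a number. Compound 2 is reported in this assay as "not toxic" (no number reported), without any figure. Going by the values given here, compound 3 is the sole compound of the set with a numerical read-out, giving 39000 nM in this assay; it therefore stands as the one fixed point. Compound 1 sits at the limit of > 100000 nM in this assay, at which 1 of the 3 values shown sits. Compound 2 carries no number at all.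

Compound 4 `O=c1[nH]cc(S(=O)(=O)Nc2ccc(-c3cn(-c4cccc(Cl)c4)nn3)cc2)c(=O)[nH]1` is not yet measured. It differs from compound 3 in one place: chloro in place of methyl on an aromatic carbon. Among the compounds with values here, no step between measured compounds is available to calibrate this change, so the working assumption is a step within the scatter, without a clear direction. For compound 4 the expected step in this assay is a 1.0-fold higher number from compound 3 to compound 4 (0.01 log units; within the scatter), and the estimated half-maximal cytotoxic concentration is 40000 nM, in the range 15000 nM to 100000 nM.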

Compound 4, half-maximal cytotoxic concentration: 19000 nM
Beside the measured number, compound 4's estimate is 2.1-fold (0.32 log units) above it, and the stated range covers the measured number.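

Going by these compounds alone, exchanging 3-methylphenyl for 3-chlorophenyl gives the only readable step for this position in this assay: a 2.1-fold lower number from compound 3 to compound 4 (0.31 log units; beyond the scatter). A swap of one heavy atom on this aromatic carbon is therefore not neutral here: the step is modest, but it lies beyond the scatter and goes toward higher toxicity in this test. Compound 1 also carries the 3-chlorophenyl group, yet its read-out is a limit and not a number: the limit of > 100000 nM in this assay, at which 1 of the 4 values shown sits.

Steps to compound 1 and compound 2 cannot be read, so it remains open whether the change from methyl to chloro would act the same way in their frameworks, and the data give no cause for the step. Also open, from the compounds shown here alone, is how a methoxy group or an amine at this position would read in this assay.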